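The compounds below may be only part of what the source reports. "The series", "measured", "known", "first", "only" and "open" are said of these compounds alone.

Measured in a functional assay on HCT-116 cells (Homo sapiens) for inhibition; a lower number here means a stronger inhibitor, a higher number a weaker inhibitor:
- compound 1 `CCNC(=O)c1noc(-c2cc(C(C)C)c(O)cc2O)c1-c1cc(COCC(=O)OC)no1`: 262 nM
- compound 2 `CCNC(=O)c1noc(-c2cc(C(C)C)c(O)cc2O)c1-c1cc(COCC(=O)O)no1`: "not determined" (no result reported)
- compound 3 `CCNC(=O)c1noc(-c2cc(C(C)C)c(O)cc2O)c1-c1cc(COCC(N)=O)no1`: 97 nM

Not yet measured: compound 4 `CCNC(=O)c1noc(-c2cc(C(C)C)c(O)cc2O)c1-c1cc(CN)no1`.

Among the compounds with values here, only two compounds have a number so far. Of these, compound 3 holds the lower value in this assay, at 97 nM, while compound 2 offers no number for comparison.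

The next change is amino in place of carbamoylmethoxy on a saturated chain carbon bound to an aromatic carbon.

Within the data shown here, one measured step bears on this change, and only indirectly: a 2.7-fold lower number from compound 1 to compound 3 (0.43 log units; beyond the scatter). That modest step, beyond the scatter, swapped amino for methoxy on a carbonyl carbon. This carbonyl lies within the carbamoylmethoxy group that compound 4 loses entirely. Among the measured compounds shown here, the step therefore shows that an edit within this group can move the number modestly, but no measured compound tests removal of the whole group. Direction is poorly defined, and a small drift towards a weaker result is a cautious assumption rather than a finding.

The expected change is a 1.6-fold higher number from compound 3 to compound 4 (0.22 log units; within the scatter), with wide uncertainty.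

Compound 4 is estimated at 160 nM, with an expected range from 45 nM to 550 nM.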

Compound 4, half-maximal inhibitory concentration: 84 nM
The estimate for compound 4 lay 1.9-fold (0.28 log units) above the measured number; low and high end bracket the measured number.
By their numbers in this assay, from the lowest: compounds 4 and 3 (each within the scatter of the next); then compound 1.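

In this assay, amino in place of carbamoylmethoxy on a saturated chain carbon bound to an aromatic carbon gives a 1.2-fold lower number from compound 3 to compound 4 (0.06 log units; within the scatter) and so stays within the scatter, which shows that the full side chain beyond this carbon, 5 heavy atoms with its carbonyl, can be exchanged for a single nitrogen without a step that can be read as a change. Amino in place of (methoxycarbonyl)methoxy at the same carbon gives a 3.1-fold lower number from compound 1 to compound 4 (0.49 log units; beyond the scatter) as a modest step beyond the scatter, so among the three compounds with numbers the methyl ester compound 1 stands apart, while compound 3 and compound 4 cannot be ordered. No supporting data bear on what lies behind these numbers.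

Open is whether the amino group itself contributes anything at this carbon, since the compounds shown do not place a hydroxyl, a dimethylamino group or a plain methyl there. Also open is how far the chain can vary, as a longer chain such as aminoethyl has no counterpart among these compounds.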